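Thiophen-3-yl in place of furan-3-yl

A few compounds are considered here, and "the series" means these few. Any claim that something is new, unique, unknown or untested is made for them only; others in the source may bear on it.

Among the measured compounds shown here, in a functional assay on K562 cells (Homo sapiens) for antiproliferative activity, with a stated time of 72 h (on this read-out higher numbers stand for weaker inhibition and lower numbers for stronger inhibition), compound 2 `COc1ccc(-c2cc([C@@H]3O[C@H](CO)[C@@H](O)[C@H]3O)n3ncnc(N)c23)cc1` gives 76400 nM, and compound 3 `Nc1ncnn2c([C@@H]3O[C@H](CO)[C@@H](O)[C@H]3O)cc(-c3ccoc3)c12` gives 2100 nM, the lowest number so far.

Compound 1 `Nc1ncnn2c([C@@H]3O[C@H](CO)[C@@H](O)[C@H]3O)cc(-c3ccccc3)c12` gives only a limit, > 100000 nM.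

Compound 4 `Nc1ncnn2c([C@@H]3O[C@H](CO)[C@@H](O)[C@H]3O)cc(-c3ccsc3)c12` differs from compound 3 by thiophen-3-yl in place of furan-3-yl on an aromatic carbon.

The nearest measured steps are both large: an at least 47-fold lower number from compound 1 to compound 3 (1.67 log units; beyond the scatter) and a 36-fold lower number from compound 2 to compound 3 (1.56 log units; beyond the scatter). Each brings in furan-3-yl in place of a phenyl or 4-methoxyphenyl group, whereas the new change keeps one five-membered aromatic ring with 1 hetero atom. For the measured compounds named here, no step of that size is therefore expected in this assay.

The expected change is a 1.1-fold lower number from compound 3 to compound 4 (0.02 log units; within the scatter), with no direction beyond the scatter.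

Compound 4 is estimated at 2000 nM, with an expected range of 500 nM to 9000 nM.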

Compound 4, half-maximal inhibitory concentration: 66400 nM
For compound 4 the middle estimate is 33-fold (1.52 log units) below the measured one; the whole stated range lies below it.
By their numbers in this assay, from the lowest: compound 3; then compounds 4 and 2 (each within the scatter of the next). At a limit, above all of these: compound 1.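

In this assay, exchanging one five-membered aromatic ring with 1 hetero atom for another, with sulfur entering for oxygen, is not a neutral change at this position: the exchange gives a 32-fold higher number from compound 3 to compound 4 (1.50 log units; beyond the scatter). Thiophen-3-yl does not share the gain seen with furan-3-yl: thiophen-3-yl in place of 4-methoxyphenyl gives a 1.2-fold lower number from compound 2 to compound 4 (0.06 log units; within the scatter). Compound 1 stands only as a limit: the limit of > 100000 nM in this assay, at which 1 of the 4 values shown sits. Thiophen-3-yl in place of phenyl gives only a floor, an at least 1.5-fold lower number from compound 1 to compound 4 (0.17 log units; that floor lies within the scatter).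

No measured property accounts for the gap between the furan-3-yl and thiophen-3-yl compounds. From the compounds shown here alone, whether a pyrrole ring or a carboxylic acid on this aromatic carbon would come closer to compound 3 remains open.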